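Benzyl triazole chromone series: cyanophenyl variant

The source may hold more compounds than are shown below. What is called first, only, known or untested is meant among the compounds shown, and "the series" means these compounds.

Compound 1 `O=c1ccoc2cc(OCc3cn(Cc4ccccc4)nn3)ccc12` gives 42900 nM in a functional assay on SW480 cells (Homo sapiens) for cytotoxicity, read by MTT assay, with a stated time of 48 h; a higher number here means a weaker inhibitor, a lower number a stronger inhibitor. Compound 2 `O=c1ccoc2cc(OCc3cn(Cc4ccc(Br)cc4)nn3)ccc12` gives 37500 nM in this assay, the lowest of the two numbers, with compound 1 nearest; the step of a 1.1-fold lower number from compound 1 to compound 2 (0.06 log units; within the scatter) lies within the scatter. Compound 3 `N#Cc1cccc(Cn2cc(COc3ccc4c(=O)ccoc4c3)nn2)c1` differs from compound 2 by 3-cyanophenyl in place of 4-bromophenyl on a saturated chain carbon bound to an aromatic nitrogen. Within the data shown here, the only measured step, a 1.1-fold lower number from compound 1 to compound 2 (0.06 log units; within the scatter), concerns the same ring and stayed within the scatter, so the expected step to compound 3 is a 1.1-fold higher number from compound 2 to compound 3 (0.03 log units; within the scatter), none beyond the scatter. In this assay compound 3 is estimated at 40000 nM, range 20000 nM to 80000 nM.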

Compound 3, half-maximal inhibitory concentration: > 100000 nM
Compound 3 was reported as a limit (the forecaster's own chance of this, stated with the estimate: 10%); middle value at least 2.5-fold (0.39 log units) away from the limit.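

Compound 3 stands in this assay only as a limit, not as a number: the limit of > 100000 nM in this assay, at which 1 of the 3 values shown sits. The ring on the saturated chain carbon bound to an aromatic nitrogen, unresponsive to bromo, now shows a change beyond the scatter: 3-cyanophenyl in place of 4-bromophenyl gives an at least 2.6-fold higher number from compound 2 to compound 3 (0.42 log units; beyond the scatter), and cyano in place of hydrogen gives an at least 2.3-fold higher number from compound 1 to compound 3 (0.36 log units; beyond the scatter). As far as these compounds go, both steps are minimum sizes, so their full extent stays unknown.

Open, from the compounds shown here alone, is whether the nitrile itself or its place on the ring carries the step, which a 4-cyanophenyl group would separate. Also open, going by these compounds, is whether an amine on this ring would give a lower number.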